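The compounds below may be only part of what the source reports. "The series", "measured", "known", "first", "only" and "open" are said of these compounds alone.

- compound 1 `O=S(=O)(CS(=O)(=O)C(F)(F)F)c1ccc(OC(F)(F)F)cc1` gives 2950000 nM
- compound 2 `O=S(=O)(CS(=O)(=O)C(F)(F)F)c1ccc(Cl)cc1` gives 4000000 nM

In a functional assay (mitochondria, liver) with Rattus norvegicus as the target (on this read-out higher numbers stand for weaker inhibition and lower numbers for stronger inhibition), compound 1 gives 2950000 nM and sits level with compound 2, within the scatter. Compound 3 `CC(S(=O)(=O)c1ccc(OC(F)(F)F)cc1)S(=O)(=O)C(F)(F)F` is compound 1 with a single change: methyl in place of hydrogen on a saturated chain carbon bound to two sulfonyl sulfurs. Going by the values given here, the only measured step (a 1.4-fold higher number from compound 1 to compound 2 (0.13 log units; within the scatter)) is a swap on an aromatic carbon, so it bears only indirectly, and no measured step touches this chain carbon. With so little evidence, no step beyond the scatter is expected, and the range stays wide. The estimated step (a 1.0-fold higher number from compound 1 to compound 3 (0.01 log units; within the scatter)) is therefore slight. The value of compound 3 is expected to be 3000000 nM (range 1000000 nM to 9000000 nM).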

Compound 3, half-maximal inhibitory concentration: 710000 nM
For compound 3 the middle estimate is 4.2-fold (0.63 log units) above the measured one; the measured number lies below the stated range.
By their numbers in this assay, from the lowest: compound 3; then compounds 1 and 2 (each within the scatter of the next).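

In this assay the step of a 4.2-fold lower number from compound 1 to compound 3 (0.62 log units; beyond the scatter) lies beyond the scatter, with methyl in place of hydrogen on a saturated chain carbon bound to two sulfonyl sulfurs. This shows that the chain carbon, untouched by the earlier pair, is a place where one added carbon shifts the number towards stronger inhibition, whereas the earlier aromatic swap stayed within the scatter. Nothing available explains this shift. Going by these compounds, whether an ethyl group or a longer chain at this carbon would shift the number further remains open. So does whether the same methyl would act alike on the chloro compound 2.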